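The source may report more compounds than this note shows. Statements on the series, on what has been measured and on what is new or still open speak of the compounds shown alone.

Compound 1 `COc1ccc(C(=O)/C=C/c2cc3ccccc3[nH]c2=O)cc1` in a functional assay on M14 cells (Homo sapiens) for cytotoxicity, read by sulforhodamine B assay, with a stated time of 24 h; on this read-out higher numbers stand for weaker inhibition of growth and lower numbers for stronger inhibition of growth: 4060 nM
Compound 2 `O=C(/C=C/c1cc2ccccc2[nH]c1=O)c1ccc(O)cc1` in this assay: 2600 nM

Of the two numbers, compound 2 has the smaller one, but the step of a 1.6-fold lower number from compound 1 to compound 2 (0.19 log units; within the scatter) lies within the scatter, so the two compounds are not distinguished. Compound 3 `O=C(/C=C/c1cc2ccccc2[nH]c1=O)c1ccc(Cl)cc1` differs from compound 2 by chloro in place of hydroxy on an aromatic carbon. Among the compounds with values here, the only measured step, a 1.6-fold lower number from compound 1 to compound 2 (0.19 log units; within the scatter), alters the same position yet involves no chloro group, and it stayed within the scatter. Within the data shown here, no measured step bears directly on this exchange. In this assay compound 3 is therefore expected close to compound 2, with an estimated step of a 1.2-fold higher number from compound 2 to compound 3 (0.06 log units; within the scatter) and no direction claimed beyond the scatter. The estimate for compound 3 is 3000 nM, range 1000 nM to 9000 nM.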

Compound 3, concentration for 50% growth inhibition: 7540 nM
Estimate against measurement, compound 3: 2.5-fold (0.40 log units) below; the range from low to high includes it.
By their numbers in this assay, from the lowest: compounds 2, 1 and 3 (each within the scatter of the next, the first and the last beyond it).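

In this assay, within the data shown here, chloro in place of hydroxy gives the first step beyond the scatter (a 2.9-fold higher number from compound 2 to compound 3 (0.46 log units; beyond the scatter)), so the group at this position can move the read-out toward weaker inhibition of growth. Chloro in place of methoxy stays within the scatter (a 1.9-fold higher number from compound 1 to compound 3 (0.27 log units; within the scatter)), so compound 1 remains undistinguished from both compound 2 and compound 3. Nothing available accounts for the separation between hydroxy and chloro.

Open, as far as these compounds go, is how an amine or a carboxylic acid at this position would read. From the compounds shown here alone, whether fluoro or bromo would track chloro is also open.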